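A few compounds are considered here, and "the series" means these few. Any claim that something is new, unique, unknown or untested is made for them only; others in the source may bear on it.

Measured in a functional assay on Bel-7402 cells (Homo sapiens) for antiproliferative activity, read by MTT assay, with a stated time of 72 h; on this read-out higher numbers stand for weaker inhibition and lower numbers for stronger inhibition:
- Compound 1 `COc1cccc(CNCc2c(C(=O)O)n(Cc3ccc(C)cc3)c3ccccc23)c1`: 21500 nM
- Compound 2 `COc1cccc(CNCc2c(C(=O)O)n(Cc3ccc(O)cc3)c3ccccc23)c1`: > 50000 nM (a limit of the assay, not a number)
- Compound 3 `COc1cccc(CNCc2c(C(=O)O)n(Cc3ccccc3)c3cc(C(C)C)ccc23)c1`: 5900 nM

Compound 3 has the lower of the two true numbers, and the gap to compound 1 lies beyond the scatter. In compound 4 `COc1cccc(CNCc2c(C(=O)O)n(Cc3ccccc3)c3ccccc23)c1`, hydrogen replaces isopropyl on an aromatic carbon (hydrogen in place of isopropyl on an aromatic carbon). Within the data shown here, no measured step makes this change. Among the measured compounds shown here, the only measured step, an at least 2.3-fold higher number from compound 1 to compound 2 (0.36 log units; beyond the scatter), is a different swap, hydroxy in place of methyl, so it shows only that one small swap can matter. Compound 4 also lacks isopropyl, like compound 1 at 21500 nM, so a rise beyond the scatter is expected in this assay. The expected step is a 3.4-fold higher number from compound 3 to compound 4 (0.53 log units; beyond the scatter). For compound 4 the estimated value is 20000 nM, with an expected range of 8000 nM to 50000 nM.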

Compound 4, half-maximal inhibitory concentration: > 50000 nM
Compound 4: a limit, no number; the forecaster's own chance of this, stated with the estimate: 15%; middle value at least 2.5-fold (0.39 log units) away from the limit.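

In this assay, the isopropyl group carries real weight: replacing it with hydrogen gives an at least 8.4-fold higher number from compound 3 to compound 4 (0.92 log units; beyond the scatter). A swap at a different place, where methyl gives way to hydrogen, gives an at least 2.3-fold higher number from compound 1 to compound 4 (0.36 log units; beyond the scatter), so the gain is not matched by that methyl. The true size of both steps stays unknown because compound 4 gives a limit, not a number: the limit of > 50000 nM in this assay, at which 2 of the 4 values shown sit.

The step between compound 2 and compound 4 cannot be read. As far as these compounds go, whether an amine or a tert-butyl group in place of isopropyl would keep the activity of compound 3 remains open.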